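Biaryl tail variation in a cinnamate amide series

A few compounds are considered here, and "the series" means these few. Any claim that something is new, unique, unknown or untested is made for them only; others in the source may bear on it.

Compound 2 `COC(=O)/C=C/c1cccc(N(Cc2ccc(-c3cccc(C(C)=O)c3)cc2)C(=O)C2CCCCC2)c1` stands as the higher of the two numbers recorded so far in an assay on isolated protein with Bile acid receptor (Homo sapiens) as the target (a lower number here means that less compound is needed, a higher number that more compound is needed for the effect), where compound 2 gives 227 nM. For the measured compounds named here, its nearest neighbour is compound 1 `COC(=O)/C=C/c1cccc(N(Cc2ccc(-c3cccc(C)c3)cc2)C(=O)C2CCCCC2)c1`, which in this assay gives 109 nM; the single step recorded, a 2.1-fold higher number from compound 1 to compound 2 (0.32 log units; beyond the scatter), is modest but beyond the scatter.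

Compound 3 `COC(=O)/C=C/c1cccc(N(Cc2ccc(-c3ccc(SC)cc3)cc2)C(=O)C2CCCCC2)c1` has not yet been measured. It differs from compound 2 in one place: 4-(methylsulfanyl)phenyl in place of 3-acetylphenyl on an aromatic carbon. Going by the values given here, no measured step covers this exact exchange. Among the compounds with values here, the step that bears on it is the one from compound 1 to compound 2, since moving to compound 3 removes the acetyl again, and that step was modest; the methylsulfanyl group and its placement on the ring have no counterpart among the measured compounds, so the remainder of the change is uncovered.

On that basis the number for compound 3 in this assay is expected to fall somewhat, with a 1.9-fold lower number from compound 2 to compound 3 (0.28 log units; within the scatter) as the estimated step, landing near compound 1. The estimate for compound 3 is 120 nM, with a range from 45 nM to 320 nM.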

Compound 3, half-maximal effective concentration: 69 nM
Compound 3: middle estimate off by 1.7-fold (0.24 log units), on the high side; low and high end bracket the measured number.
By their numbers in this assay, from the lowest: compounds 3 and 1 (each within the scatter of the next); then compound 2.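

In this assay, the 4-(methylsulfanyl)phenyl group on this aromatic carbon gives a 3.3-fold lower number from compound 2 to compound 3 (0.52 log units; beyond the scatter) and so clears the rise seen with the 3-acetylphenyl group. Set against the 3-methylphenyl group, the same group gives a 1.6-fold lower number from compound 1 to compound 3 (0.20 log units; within the scatter) and therefore cannot be told apart from it in this assay. Of the three groups at this position, only the 3-acetylphenyl group of compound 2 stands apart, so the position tolerates a sulfur-bearing group without a rise in the number, at least in this one example.

Going by these compounds, each exchange to compound 3 changes the substituent and its place on the ring together, so the two contributions remain unseparated until a 3-(methylsulfanyl)phenyl or a 4-acetylphenyl group is compared, and a ring carrying an amine or a carboxylic acid also remains open. No measurement at hand gives a reason for any of these differences.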